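Open-chain pentan-3-yl in place of cyclohexyl: compound 4

A few compounds are considered here, and "the series" means these few. Any claim that something is new, unique, unknown or untested is made for them only; others in the source may bear on it.

Compound 1 `c1ccc(-c2ccc3c(NCCCNCc4ccco4)ccnc3c2)cc1`, compound 2 `c1coc(CNCCCNc2ccnc3cc(CC4CCCCC4)ccc23)c1` and compound 3 `c1coc(CNCCCNc2ccnc3cc(C4CCCCC4)ccc23)c1` share one core and differ only in the group attached to one aromatic carbon of that core. In an ADME assay on HepG2 cells (Homo sapiens) for cytotoxicity, read by luminescence, CellTiter-Glo and ATP content, with a stated time of 72 h (a higher number here means that more compound is needed for the effect, a lower number that less compound is needed), compound 1 gives 5920 nM, compound 2 gives 1700 nM and compound 3 gives 4760 nM. Compound 3 holds the second highest of the three numbers: its nearest neighbour is compound 1, since a 1.2-fold lower number from compound 1 to compound 3 (0.09 log units; within the scatter), and its furthest is compound 2, since a 2.8-fold higher number from compound 2 to compound 3 (0.45 log units; beyond the scatter).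

The next member is compound 4 `CCC(CC)c1ccc2c(NCCCNCc3ccco3)ccnc2c1`, reached by pentan-3-yl in place of cyclohexyl on an aromatic carbon. Among the compounds with values here, no measured step exchanges a ring group for an open chain at this carbon, so the bearing of the two known steps is indirect. Exchanging phenyl for cyclohexyl left the number where it was, whereas inserting one carbon between the core and the ring, read in reverse, gave a modest shift. Trading a six-carbon ring for a five-carbon chain of comparable bulk is therefore expected to move the number little, if at all, beyond the scatter. Compound 4 is estimated at 4000 nM, with a range from 1500 nM to 10000 nM. The expected step is a 1.2-fold lower number from compound 3 to compound 4 (0.08 log units; within the scatter).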

Compound 4, half-maximal effective concentration: 6760 nM
For compound 4 the middle estimate is 1.7-fold (0.23 log units) below the measured one; measured number inside the range.
By their numbers in this assay, from the lowest: compound 2; then compounds 3, 1 and 4 (each within the scatter of the next).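

In this assay, within the data shown here, pentan-3-yl is the first group without a ring at this aromatic carbon, and a 1.4-fold higher number from compound 3 to compound 4 (0.15 log units; within the scatter) shows that exchanging cyclohexyl for this open chain does not separate the two. The comparison with the aromatic ring gives the same reading, with a 1.1-fold higher number from compound 1 to compound 4 (0.06 log units; within the scatter) placing pentan-3-yl level with phenyl, so a ring directly on this carbon is not required to hold the number at this level. Cyclohexylmethyl remains the only group that stands apart, and a 4.0-fold higher number from compound 2 to compound 4 (0.60 log units; beyond the scatter) extends that separation to the open chain, with compound 2 as the sole exception to an otherwise flat set of groups.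

Still open, from the compounds shown here alone, is whether an amine, a carboxylic acid or a longer chain such as n-hexyl at this carbon would stay at the level of compound 1, compound 3 and compound 4, and whether the lower number with cyclohexylmethyl depends on its ring at all. Nothing available here explains why these groups give the numbers they do.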